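The source may report more compounds than this note shows. Statements on the series, on what has been measured and on what is new or still open speak of the compounds shown alone.

Measured in a functional assay on MDA-MB-231 cells (Homo sapiens) for antiproliferative activity, read by MTT assay, with a stated time of 72 h; on this read-out lower numbers stand for stronger inhibition and higher numbers for weaker inhibition:

- compound 1 `O=C(CCc1cccc2c1B(O)OC2)Nc1cccc(Br)c1`: 720 nM
- compound 2 `C#Cc1cccc(NC(=O)CCc2cccc3c2B(O)OC3)c1`: 1600 nM

Compound 2, at 1600 nM, carries the higher of the two numbers in this assay, so it is the weaker of the pair. For the measured compounds named here, its only neighbour is compound 1 at 720 nM.

The next compound, compound 3 `O=C(CCc1cccc2c1B(O)OC2)Nc1cccc(-c2cccc(F)c2)c1`, has not yet been measured. It carries 3-fluorophenyl in place of ethynyl on an aromatic carbon. The group sits meta to a large group, and the rest of the structure is unchanged.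

Going by the values given here, only one measured step bears on this change, and it also swaps one group for another at that aromatic carbon. That step, a 2.2-fold higher number from compound 1 to compound 2 (0.35 log units; beyond the scatter), is modest. Among the compounds with values here, no measured compound carries a second aromatic ring at this place, so the data give no direction for the new change. Within the data shown here, with only that modest step as a guide, no change clearly beyond the scatter is expected in this assay. The expected step is a 1.5-fold lower number from compound 2 to compound 3 (0.16 log units; within the scatter). For compound 3 the estimated value is 1100 nM, with an expected range from 300 nM to 4000 nM.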

Compound 3, half-maximal inhibitory concentration: 570 nM
Estimate against measurement, compound 3: 1.9-fold (0.29 log units) above; measured number inside the range.
By their numbers in this assay, from the lowest: compounds 3 and 1 (each within the scatter of the next); then compound 2.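

In this assay this aromatic carbon, so far seen with only bromo and ethynyl, proves able to carry a second aromatic ring: 3-fluorophenyl in place of ethynyl gives a 2.8-fold lower number from compound 2 to compound 3 (0.45 log units; beyond the scatter) and so brings the number back down. Set against bromo, the same group gives a 1.3-fold lower number from compound 1 to compound 3 (0.10 log units; within the scatter) and no order can be drawn between these two compounds, which leaves ethynyl as the one group of the three that stands apart, with compound 2 the weakest of the set. The much larger group, with its 7 heavy atoms against the 2 of ethynyl, is thus tolerated here, but nothing available explains why these numbers fall as they do.

The compounds shown leave open whether the fluorine contributes anything or the six-membered ring alone accounts for the step, as an unsubstituted phenyl would show. How an amine or a carboxylic acid on the added ring, or a longer chain at this carbon, would read in this assay also remains an open question.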